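A few compounds are considered here, and "the series" means these few. Any claim that something is new, unique, unknown or untested is made for them only; others in the source may bear on it.

The measured compounds:

Compound 1 `COc1nc(N)nc2c1c(-c1cc3ccccc3o1)cn2[C@@H]1O[C@H](CO)[C@@H](O)[C@H]1O` gives, in a functional assay on HCT-116 cells (Homo sapiens), read by MTT assay, with a stated time of 72 h (on this read-out higher numbers stand for weaker inhibition and lower numbers for stronger inhibition), > 20000 nM, which is a limit of the assay rather than a number.
Compound 2 `Nc1nc(N)c2c(-c3ccoc3)cn([C@@H]3O[C@H](CO)[C@@H](O)[C@H]3O)c2n1` gives in this assay > 20000 nM, again only a limit.
Compound 3 `COc1nc(N)nc2c1c(-c1ccccc1)cn2[C@@H]1O[C@H](CO)[C@@H](O)[C@H]1O` gives in this assay > 20000 nM, also a limit.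

Compound 3 therefore stands where every compound here stands: at the limit of > 20000 nM in this assay, at which 3 of the 3 values shown sit. Within the data shown here, no compound has a number that can be ranked against another. Among the measured compounds shown here, the one single-point step among them, a step that the two limits leave unreadable from compound 1 to compound 3, cannot be read in size or direction, since both ends sit at the limit.

Compound 4 `COc1nc(N)nc2c1c(-c1ccoc1)cn2[C@@H]1O[C@H](CO)[C@@H](O)[C@H]1O` differs from compound 3 in one place: furan-3-yl in place of phenyl on an aromatic carbon. Compound 2 carries the same furan-3-yl group on a different core, and it too reached only the limit. Nothing in the three values shown points to a readable step, so the step from compound 3 to compound 4 is expected to be a step that the limit leaves unreadable from compound 3 to compound 4, no more than the scatter would allow. Compound 4 is expected to give about 35000 nM, with a range from 15000 nM to 120000 nM, and most likely once more only a limit.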

Compound 4, half-maximal inhibitory concentration: > 20000 nM
Compound 4: only a limit was reported (the forecaster's own chance of this, stated with the estimate: 85%); the middle value lies beyond the limit too.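

Compound 4 also gives only a limit, so its steps from compound 1, compound 2 and compound 3 cannot be read in size or direction; all four compounds sit at the same point: the limit of > 20000 nM in this assay, at which 4 of the 4 values shown sit.

The compounds shown leave open which change, if any, would give a real number in this assay.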